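The compounds below may be only part of what the source reports. "The series", "measured", "known", "first", "only" and "open" are said of these compounds alone.

Of the compounds shown here, three have been measured in an assay on isolated protein for inhibition of Amine oxidase [flavin-containing] A (Homo sapiens), read by fluorescence; on this read-out lower numbers stand for stronger inhibition and higher numbers for weaker inhibition. Compound 1 `O=C(/C=C/c1cccs1)c1cc(O)c(O)c([N+](=O)[O-])c1` gives 49900 nM, compound 2 `O=C(/C=C/c1cccc(O)c1)c1cc(O)c(O)c([N+](=O)[O-])c1` gives 43900 nM, and compound 3 `CC(=O)N1N=C(c2cc(O)c(O)c([N+](=O)[O-])c2)CC1c1cccs1` gives 86300 nM. Compound 3 has the highest of the three numbers, but its gaps to compound 1 and to compound 2 both sit within the scatter, so none of the three can be called the stronger or weaker inhibitor.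

Compound 4 `CC(=O)N1N=C(c2cc(O)c(O)c([N+](=O)[O-])c2)CC1c1cccc(O)c1` has not yet been measured. It differs from compound 3 in one place: 3-hydroxyphenyl in place of thiophen-2-yl on a saturated ring carbon. The same exchange has already been seen once, on a double-bonded chain carbon, where the step from compound 1 to compound 2 gave a 1.1-fold lower number from compound 1 to compound 2 (0.06 log units; within the scatter). Within the data shown here, that single precedent is the only guide, and it suggests no movement beyond the scatter in this assay. The step from compound 3 to compound 4 is therefore expected to be about a 1.1-fold lower number from compound 3 to compound 4 (0.03 log units; within the scatter). Compound 4 is thus estimated to give about 80000 nM, within a range of 40000 nM to 160000 nM.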

Compound 4, half-maximal inhibitory concentration: 87000 nM
For compound 4 the middle estimate is 1.1-fold (0.04 log units) below the measured one, within the range that was stated.
By their numbers in this assay, from the lowest: compounds 2, 1, 3 and 4 (each within the scatter of the next).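

In this assay, 3-hydroxyphenyl in place of thiophen-2-yl on the saturated ring carbon gives a 1.0-fold higher number from compound 3 to compound 4 (0.00 log units; within the scatter), so the exchange produces no readable change at this position. Among these compounds, until now it had been seen only on a double-bonded chain carbon, as a 1.1-fold lower number from compound 1 to compound 2 (0.06 log units; within the scatter); the same exchange now stays within the scatter in two different settings, even though the entering group brings a hydrogen-bond donor that thiophen-2-yl lacks. No available measurement explains this flat result.

Going by these compounds, all four numbers lie close together, so it remains open whether any group on this saturated ring carbon can move the read-out beyond the scatter. An amine or a carboxylic acid at this position, or a longer chain in place of the acetyl group, would put that question to the test.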